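Changing the Amide Aryl Group: Estimating Compound 3

The source may hold more compounds than are shown below. What is called first, only, known or untested is meant among the compounds shown, and "the series" means these compounds.

Compound 1 `CCN1CCN(c2cc(C)c3cc(NC(=O)c4cccc(C)c4)ccc3n2)CC1`: 13700 nM
Compound 2 `CCN1CCN(c2cc(C)c3cc(NC(=O)c4ccccc4Br)ccc3n2)CC1`: 39200 nM

Of the compounds shown here, two built on a shared core have been measured in a functional assay on SK-BR-3 cells (Homo sapiens) for antiproliferative activity, read by MTT assay, with a stated time of 72 h; a lower number here means a stronger inhibitor, a higher number a weaker inhibitor. Compound 2 gives the highest number of the two; the nearest is compound 1, and a 2.9-fold higher number from compound 1 to compound 2 (0.46 log units; beyond the scatter) places the two beyond the scatter of each other. Compound 3 `CCN1CCN(c2cc(C)c3cc(NC(=O)c4ccc5ccccc5n4)ccc3n2)CC1` carries a different group on the carbonyl carbon: quinolin-2-yl in place of 2-bromophenyl on a carbonyl carbon. For the measured compounds named here, no measured step swaps in a group of this kind, so the only step available, a 2.9-fold higher number from compound 1 to compound 2 (0.46 log units; beyond the scatter), shows merely that exchanging the group on this carbonyl carbon can shift the number modestly but beyond the scatter. Compound 3 is therefore expected to move only modestly, here toward a lower number, giving an expected step of a 2.6-fold lower number from compound 2 to compound 3 (0.42 log units; beyond the scatter). The estimate for compound 3 in this assay is 15000 nM, within the expected range 4000 nM to 60000 nM.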

Compound 3, half-maximal inhibitory concentration: 3760 nM
The estimate for compound 3 lay 4.0-fold (0.60 log units) above the measured number, and the stated range ends above it.
By their numbers in this assay, from the lowest: compound 3; then compound 1; then compound 2.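

In this assay, quinolin-2-yl in place of 2-bromophenyl on the carbonyl carbon gives a 10-fold lower number from compound 2 to compound 3 (1.02 log units; beyond the scatter), so this position can move the number much further than the earlier pair of compounds showed. The same group in place of 3-methylphenyl gives a 3.6-fold lower number from compound 1 to compound 3 (0.56 log units; beyond the scatter) and a lower number again, so the drop is seen against both phenyl groups measured so far. The change also adds more than one feature at once: a second six-membered aromatic ring and a ring nitrogen counted as a hydrogen-bond acceptor.

Nothing available explains why the number falls. Going by these compounds, whether the second ring or the ring nitrogen matters stays open; naphthalen-2-yl, with the second ring but no nitrogen, and pyridin-2-yl, with the nitrogen but no second ring, are groups that could separate the two.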